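Moving a Chlorine and Lengthening the Linker

This account rests on a few compounds, and the source may have more. Where it says the series, first, only, none or still open, it means among the compounds named here.

Of the compounds shown here, three have been measured in an assay on isolated protein for inhibition of Amine oxidase [flavin-containing] B (Homo sapiens), read by fluorescence and spectrophotometry; a higher number here means a weaker inhibitor, a lower number a stronger inhibitor.
Compound 1 `Cc1ccc(NC(=O)CCCCc2cn(Cc3ccc4oc(-c5ccc(Cl)cc5)cc(=O)c4c3)nn2)cc1` gives 32900 nM.
Compound 2 `O=C(CCc1cn(Cc2ccc3oc(-c4ccccc4)cc(=O)c3c2)nn1)Nc1ccc(Cl)cc1` gives 15600 nM.
Compound 3 `O=C(CCc1cn(Cc2ccc3oc(-c4ccc(Cl)cc4)cc(=O)c3c2)nn1)Nc1ccccc1` gives 32900 nM.

Among these three, compound 2 has the lowest number, and both compound 1 and compound 3 sit beyond the scatter above it, each by the same margin. Compound 4 `O=C(CCCCc1cn(Cc2ccc3oc(-c4ccccc4)cc(=O)c3c2)nn1)Nc1ccccc1` has not yet been measured. It differs from compound 2 in one place: 2-(phenylcarbamoyl)ethyl in place of (4-chlorophenyl)carbamoyl on a saturated chain carbon, two bonds along the chain from an aromatic carbon. Put simply, the chlorine on the anilide ring is removed and the chain between the triazole and the amide grows by two carbons.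

One measured step speaks to part of this. Between compound 1 and compound 3 the chain was shortened by two carbons while a methyl left the anilide ring, and the result was no change at the digits printed from compound 1 to compound 3 (within the scatter). That suggests chain length alone matters little here. Within the data shown here, the removal of the chlorine from the anilide has no direct precedent; the only hint is that compound 2 gives 15600 nM while compound 3, which carries its chlorine on the other ring instead, gives 32900 nM.

Compound 4 is therefore expected to land near 25000 nM, somewhere between 10000 nM and 60000 nM. That expectation corresponds to a step of a 1.6-fold higher number from compound 2 to compound 4 (0.20 log units; within the scatter).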

Compound 4, half-maximal inhibitory concentration: 15600 nM
Compound 4: the middle estimate sits 1.6-fold (0.20 log units) above what was measured; the measured number falls inside the stated range.
By their numbers in this assay, from the lowest: compounds 2 and 4 (each within the scatter of the next); then compounds 1 and 3 (each within the scatter of the next).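

At this position, on a saturated chain carbon, two bonds along the chain from an aromatic carbon, 2-(phenylcarbamoyl)ethyl in place of (4-chlorophenyl)carbamoyl gives no change at the digits printed from compound 2 to compound 4 (within the scatter), so removing the anilide chlorine and adding two chain carbons together leaves the reading unmoved. The earlier step, no change at the digits printed from compound 1 to compound 3 (within the scatter), shortened the chain and removed a methyl, so the chain has now been changed in both directions, each time with a change on the anilide ring, and neither pair shows a shift beyond the scatter. No other data here bear on why the reading holds steady.

Each of these two steps alters the chain and the anilide ring at once, so they cannot show whether each edit alone has no effect or whether two opposing effects happen to cancel. Also open, as far as these compounds go, is how this position would respond to a still longer chain, or to a carboxylic acid or an amine in place of the anilide.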